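Side-chain amine exchange on compound 3

This account rests on a few compounds, and the source may have more. Where it says the series, first, only, none or still open, it means among the compounds named here.

Measured so far:
compound 1, `CC1=NN(C(=O)c2ccc(C)cc2)C(c2ccccc2O)C1`, in a functional assay on PC-3 cells (Homo sapiens) for cytotoxicity, read by MTT assay, with a stated time of 48 h (on this read-out lower numbers stand for stronger inhibition and higher numbers for weaker inhibition), gives 40600 nM
compound 2, `CC1=NN(S(=O)(=O)c2ccc([N+](=O)[O-])cc2)C(c2cc(Br)cc(Br)c2O)C1`, in this assay gives 50000 nM
compound 3, `CNCC(=O)N1N=C(c2cc3ccccc3oc2=O)CC1c1ccccc1`, in this assay gives 2300 nM

Compound 3 stands lowest of the three numbers; its gaps to compound 1 and to compound 2 both lie beyond the scatter. Within the data shown here, no pair of the measured compounds differs in a single place, so no measured step exists for comparison, and compound 1 and compound 2 share only the shape of the core with compound 3, not its side chain.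

Compound 4, `CC1CCCCN1CC(=O)N1N=C(c2cc3ccccc3oc2=O)CC1c1ccccc1`, differs from compound 3 in one place: 2-methylpiperidin-1-yl in place of methylamino on a saturated chain carbon bound to a carbonyl carbon. The side chain keeps its carbonyl and one acceptor and loses its donor.

Among the measured compounds shown here, with no measured step of this kind, the expected step from compound 3 to compound 4 is a 1.3-fold higher number from compound 3 to compound 4 (0.12 log units; within the scatter), which is estimated to fall within the scatter, with no clear direction. Compound 4 is therefore expected to give about 3000 nM in this assay, estimated within 800 nM to 12000 nM.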

Compound 4, half-maximal inhibitory concentration: 36300 nM
Beside the measured number, compound 4's estimate is 12-fold (1.08 log units) below it, and the stated range ends below it.
By their numbers in this assay, from the lowest: compound 3; then compounds 4, 1 and 2 (each within the scatter of the next).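

In this assay, among these compounds, the side-chain amine on the saturated chain carbon bound to a carbonyl carbon proves to matter: 2-methylpiperidin-1-yl in place of methylamino gives the only measured single-place step (a 16-fold higher number from compound 3 to compound 4 (1.20 log units; beyond the scatter)), and it lies beyond the scatter. Compound 1 and compound 2 differ from compound 3 in more than one place and could not show this sensitivity, which compound 4 now establishes for this position. Nothing at hand gives a reason for the size of this step.

This single step changes the heavy-atom count, the ring and the hydrogen-bond donor together, so their contributions remain unseparated. Dimethylamino, piperidin-1-yl without the methyl group, and morpholin-4-yl at this position would leave open different parts of that change, and how each compares with methylamino remains unknown.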